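From a Methoxy to an Ethoxy Group: Compound 4

The source may hold more compounds than are shown below. What is called first, only, known or untested is meant among the compounds shown, and "the series" means these compounds.

Of the compounds shown here, three have been measured in a functional assay on MCF7 cells (Homo sapiens) for cytotoxicity, read by XTT assay, with a stated time of 24 h; a lower number here means a stronger inhibitor, a higher number a weaker inhibitor. Compound 1 `CC(=O)Oc1cc(C)c(Cl)c2c1C(=O)C=CC2=O` gives 37900 nM, compound 2 `COc1cc(C)cc2c1C(=O)C=CC2=O` gives 15300 nM, and compound 3 `COc1cc(C)c(Cl)c2c1C(=O)C=CC2=O` gives 20600 nM. Compound 2 stands lowest of these three numbers; its gap to compound 3 is within the scatter, while its gap to compound 1 is beyond it. Compound 4 `CCOc1cc(C)cc2c1C(=O)C=CC2=O` differs from compound 2 in one place: methyl in place of hydrogen on a saturated chain carbon bound to an oxygen on an aromatic ring. The measured step nearest in kind is a 1.8-fold lower number from compound 1 to compound 3 (0.26 log units; within the scatter), also a change of the group on an oxygen on an aromatic ring; the other step, a 1.3-fold higher number from compound 2 to compound 3 (0.13 log units; within the scatter), concerns a different site. Both lay within the scatter, so no step beyond the scatter is expected in this assay, in either direction. Compound 4 is therefore estimated at 15000 nM, within 7000 nM to 32000 nM, meaning an expected step of a 1.0-fold lower number from compound 2 to compound 4 (0.01 log units; within the scatter).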

Compound 4, half-maximal inhibitory concentration: 23700 nM
For compound 4 the middle estimate is 1.6-fold (0.20 log units) below the measured one; the range from low to high includes it.
By their numbers in this assay, from the lowest: compounds 2, 3, 4 and 1 (each within the scatter of the next, the first and the last beyond it).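

In this assay the exchange of methoxy for ethoxy reads a 1.5-fold higher number from compound 2 to compound 4 (0.19 log units; within the scatter) and so separates neither compound from the other. Compound 2 and compound 4 are the first pair shown in which the group on this oxygen remains an ether, and one added methyl here makes no difference that can be read. No evidence is available to explain this result. The compounds shown leave open whether a longer chain on this oxygen, or an amine in place of the ether, would give a step beyond the scatter. They also leave open whether ethoxy would read the same in the chloro-bearing core of compound 3.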